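A few compounds are considered here, and "the series" means these few. Any claim that something is new, unique, unknown or untested is made for them only; others in the source may bear on it.

Working notes on the series. Compound 3 `COc1cc2c(Oc3ccc(NC(=O)c4nn(-c5ccc(Cl)cc5)c(=O)cc4C)cc3F)ccnc2cc1OCCCN1CCC(C)CC1` gives 180 nM in a functional assay on HT-29 cells (Homo sapiens) for inhibition, read by MTT assay, with a stated time of 72 h (on this read-out higher numbers stand for weaker inhibition and lower numbers for stronger inhibition), the lowest of the three numbers, though its gap to compound 1 lies within the scatter. Compound 1 `COc1cc2c(Oc3ccc(NC(=O)c4nn(-c5cccc(F)c5)c(=O)cc4C)cc3F)ccnc2cc1OCCCN1CCC(C)CC1` gives 300 nM in this assay, and a 1.7-fold lower number from compound 1 to compound 3 (0.22 log units; within the scatter). Compound 2 `COc1ccc(-n2nc(C(=O)Nc3ccc(Oc4ccnc5cc(OCCCN6CCC(C)CC6)c(OC)cc45)c(F)c3)c(C)cc2=O)cc1` gives 5450 nM in this assay; a 30-fold lower number from compound 2 to compound 3 (1.48 log units; beyond the scatter), and an 18-fold higher number from compound 1 to compound 2 (1.26 log units; beyond the scatter). Compound 4 `COc1cc2c(Oc3ccc(NC(=O)c4nn(-c5ccc(Cl)cc5Cl)c(=O)cc4C)cc3F)ccnc2cc1OCCCN1CCC(C)CC1` differs from compound 3 by chloro in place of hydrogen on an aromatic carbon. For the measured compounds named here, no measured step adds a second halogen to this ring; the bearing steps show only that the 4-chlorophenyl is accepted, a 1.7-fold lower number from compound 1 to compound 3 (0.22 log units; within the scatter), while the methoxy is not. Compound 3 is therefore expected to be matched, within the scatter, by compound 4 a 1.4-fold higher number from compound 3 to compound 4 (0.14 log units; within the scatter). Compound 4 is expected at 250 nM, range 80 nM to 800 nM.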

Compound 4, half-maximal inhibitory concentration: 170 nM
Compound 4: the middle estimate sits 1.5-fold (0.17 log units) above what was measured; the measured number falls inside the stated range.
By their numbers in this assay, from the lowest: compounds 4, 3 and 1 (each within the scatter of the next); then compound 2.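

In this assay, a second chloro ortho to a large group is accepted, with no change beyond the scatter (a 1.1-fold lower number from compound 3 to compound 4 (0.02 log units; within the scatter)). The 2,4-dichlorophenyl also stays level with the 3-fluorophenyl (a 1.8-fold lower number from compound 1 to compound 4 (0.25 log units; within the scatter)) and remains well apart from the 4-methoxyphenyl (a 32-fold lower number from compound 2 to compound 4 (1.51 log units; beyond the scatter)). No evidence on hand accounts for these steps.

On these data alone, whether an amine or a carboxylic acid at this place would be accepted as chloro is remains open. So does whether a methoxy group there would match chloro.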